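A Trifluoromethyl Removed Where Nothing Yet Moved

This account rests on a few compounds, and the source may have more. Where it says the series, first, only, none or still open, it means among the compounds named here.

Measured compounds:
Compound 1, `O=C(Nc1cccc(-n2cc(-c3ccncc3)c(-c3cc(O)cc(Cl)c3)n2)c1)Nc1ccc(Cl)c(C(F)(F)F)c1`, gives 104% in a functional assay on UACC-62 cells (Homo sapiens) for inhibition, read by sulforhodamine B assay, with a stated time of 48 h, tested at 0.01 uM; on this read-out lower numbers stand for a stronger effect and higher numbers for a weaker effect at the one concentration tested.
Compound 2, `COc1cc(Cl)cc(-c2nn(-c3cccc(NC(=O)Nc4cc(C(F)(F)F)cc(C(F)(F)F)c4)c3)cc2-c2ccncc2)c1`, gives 96% in this assay.

Both numbers sit close to the untreated level, so neither compound shows a clear effect at the one concentration tested. Compound 2 is the lower of the two numbers, but its nearest neighbour, compound 1, sits only a little higher, and that gap lies within the scatter of repeated measurements; no word of order between the two is warranted.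

Compound 3, `COc1cc(Cl)cc(-c2nn(-c3cccc(NC(=O)Nc4cccc(C(F)(F)F)c4)c3)cc2-c2ccncc2)c1`, is the next compound, unmeasured. It differs from compound 2 in one place: hydrogen in place of trifluoromethyl on an aromatic carbon.

Within the data shown here, no single-change step between measured compounds exists here, so the size of this change cannot be read from the data. With both measured compounds showing no effect, the expectation is that the step from compound 2 to compound 3 stays within the scatter, and the estimate means a step of a number 2 percentage points higher from compound 2 to compound 3 (within the scatter). Compound 3 is therefore expected to give 98% in this assay, with a range from 87% to 108%.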

Compound 3, a percentage reported as activity, at one concentration (the size of the read-out at that concentration, not a potency): 96%
For compound 3 the middle estimate is 2 percentage points above the measured one, and the stated range covers the measured number.
By their numbers in this assay, from the lowest: compounds 2, 3 and 1 (each within the scatter of the next).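

In this assay, among these compounds, the replacement of trifluoromethyl by hydrogen on an aromatic carbon, meta to a large group and meta to a trifluoromethyl group, gives the first comparison in this set that differs in one place, and it reads as no change at the digits printed from compound 2 to compound 3 (within the scatter) in the percentage measured. At this position, then, the loss of a trifluoromethyl group with its four heavy atoms leaves the read-out unmoved at the one concentration tested, which the earlier pair, differing in more than one place, could not show. Among the compounds shown here, since both compounds sit close to the untreated level, this step says only that the change brought out no effect here, not that the group is without consequence under conditions where the series shows an effect, and nothing measured on these compounds offers an explanation for the flat result.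

As far as these compounds go, whether any other group at this carbon, such as an amine, a carboxylic acid or a longer chain, would move the number remains open. So does the question of whether this same exchange would leave the read-out unmoved at a concentration where the compounds produce a clear effect.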